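Removing the methyl from compound 2

This account rests on a few compounds, and the source may have more. Where it says the series, first, only, none or still open, it means among the compounds named here.

compound 1 `NCC1(c2cccc(-c3ccnc4[nH]ncc34)c2)CCC1`: 17 nM
compound 2 `Cc1cc(-c2ccnc3[nH]nc(C(F)(F)F)c23)cc(C2(CN)CCC2)c1`: 3 nM

In an assay for inhibition of protein kinase C theta type (Homo sapiens), read by scintillation counting and 33P incorporation, with a stated time of 60 min, in the presence of a further agent that is not named here (a lower number here means a stronger inhibitor, a higher number a weaker inhibitor), compound 2 gives 3 nM, the lower of the two numbers. Compound 1, which differs from it in two places, gives 17 nM, a gap beyond the scatter. Compound 3 `NCC1(c2cccc(-c3ccnc4[nH]nc(C(F)(F)F)c34)c2)CCC1` differs from compound 2 by hydrogen in place of methyl on an aromatic carbon. Among the measured compounds shown here, no measured pair isolates this change, and the gap between compound 1 and compound 2 mixes it with the trifluoromethyl. A small loss, within or just beyond the scatter, is expected in this assay. Compound 3 is estimated at 6 nM (range 2 nM to 18 nM), an expected step of a 2.0-fold higher number from compound 2 to compound 3 (0.30 log units; within the scatter).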

Compound 3, inhibition constant in the protein kinase C theta type assay: 2 nM
Beside the measured number, compound 3's estimate is 3.0-fold (0.48 log units) above it; measured number inside the range.
By their numbers in the protein kinase C theta type assay, from the lowest: compounds 3 and 2 (each within the scatter of the next); then compound 1.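

In the protein kinase C theta type assay, hydrogen in place of methyl on this aromatic carbon gives a 1.5-fold lower number from compound 2 to compound 3 (0.18 log units; within the scatter), with compound 2 at 3 nM and compound 3 at 2 nM, so the position tolerates loss of the methyl. In the same assay, compound 1 and compound 3 isolate the other change: trifluoromethyl in place of hydrogen on an aromatic carbon gives an 8.5-fold lower number from compound 1 to compound 3 (0.93 log units; beyond the scatter). In a physicochemical assay for acid dissociation, removing the methyl gives no change at the digits printed from compound 2 to compound 3 (within the scatter), with compound 2 at 8.8 and compound 3 at 8.8.

Open, going by these compounds, is whether a methoxy group, a chlorine or an amine on this carbon would hold the inhibition seen here. No measurement shown gives a reason for either step.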